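Sulfone series: thiophene for chlorophenyl on the sulfonyl carbon

A few compounds are considered here, and "the series" means these few. Any claim that something is new, unique, unknown or untested is made for them only; others in the source may bear on it.

Compound 1 `CCOC(=O)C1=CCCCC1S(=O)(=O)Cc1ccccc1Cl` gives 14 nM; 1200 nM; 11 nM (3 entries) in a functional assay on RAW264.7 cells (Mus musculus), read by fluorescence (on this read-out higher numbers stand for weaker inhibition and lower numbers for stronger inhibition), a spread that the several entries of compound 1 in this assay, 14 nM; 1200 nM; 11 nM (3 entries) makes plain. For the measured compounds named here, compound 2 `CCOC(=O)C1=CCCCC1S(=O)(=O)Cc1ccc(Cl)cc1` gives 101 nM in this assay; this is the only number for it, and a further entry carries no single number. Compound 3 `CCOC(=O)C1=CCCCC1S(=O)(=O)Cc1ccsc1` remains to be measured. The change is thiophen-3-yl in place of 4-chlorophenyl on a saturated chain carbon bound to a sulfonyl sulfur. Going by the values given here, no measured step of this kind exists in the set, so the step from compound 2 to compound 3 is expected to be a 2.2-fold higher number from compound 2 to compound 3 (0.34 log units; beyond the scatter), a modest weakening that may only just exceed the scatter. Compound 3 is therefore estimated at 220 nM, with a range of 60 nM to 800 nM.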

Compound 3, half-maximal inhibitory concentration: 105 nM
Beside the measured number, compound 3's estimate is 2.1-fold (0.32 log units) above it, and the stated range covers the measured number.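

For the compounds shown here, on a saturated chain carbon bound to a sulfonyl sulfur, thiophen-3-yl replaces 4-chlorophenyl with a 1.0-fold higher number from compound 2 to compound 3 (0.02 log units; within the scatter) in this assay and is the only step available at this position. The position therefore accepts a five-membered aromatic ring, and the chlorine of compound 2 is not required to keep this level of inhibition. Compound 1 gives no firm reference for where the chlorine sits on the phenyl ring: the several entries of compound 1 in this assay, 14 nM; 1200 nM; 11 nM (3 entries).

Still open, as far as these compounds go, is whether an aromatic ring is needed here at all. An amine, a carboxylic acid or a longer chain at this carbon would test that.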